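A few compounds are considered here, and "the series" means these few. Any claim that something is new, unique, unknown or untested is made for them only; others in the source may bear on it.

Working notes on the series. Compound 1 `O=c1[nH]c(=O)n([C@H]2C[C@H](O)[C@@H](CO)O2)cc1C#CC#Cc1ccccc1` gives in an ADME assay on HEL cells (Homo sapiens) for cytotoxicity, read by microscopy (on this read-out lower numbers stand for higher toxicity in this test and higher numbers for lower toxicity in this test), a value of 100000 nM. Compound 2 `CCCc1ccc(C#CC#Cc2cn([C@H]3C[C@H](O)[C@@H](CO)O3)c(=O)[nH]c2=O)cc1` gives in this assay a value of 100000 nM. For compound 3 `COc1cc(C#CC#Cc2cn([C@H]3C[C@H](O)[C@@H](CO)O3)c(=O)[nH]c2=O)cc(OC)c1` only a limit is reported in this assay, namely > 100000 nM. Compound 3 therefore stands at the top of the measured range, at the limit of > 100000 nM in this assay, at which 1 of the 3 values shown sits, and its true number is open upward.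

The measured steps: no change at the digits printed from compound 1 to compound 2 (within the scatter); a number no lower from compound 1 to compound 3 (the limit leaves the size open); a number no lower from compound 2 to compound 3 (the limit leaves the size open). None of the three moved the read-out downward, and the two exchanges at the triple-bonded carbon left the number no lower.

Next compound 4 `O=c1[nH]c(=O)n([C@H]2C[C@H](O)[C@@H](CO)O2)cc1C#CC#Cc1ccccn1`, where the change is pyridin-2-yl in place of 3,5-dimethoxyphenyl on a triple-bonded carbon. The two prior exchanges at this same triple-bonded carbon bear on it most directly, and both gave a number no lower; the propyl step gave no change within the scatter. For compound 4 the expectation is therefore no step beyond the scatter, a number no higher from compound 3 to compound 4 (the limit leaves the size open). Compound 4 is accordingly expected to give about 100000 nM, within 50000 nM to 200000 nM, with a fair chance that only a limit is reported again.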

Compound 4, minimum cytotoxic concentration: > 20000 nM
Compound 4: no number, only a limit; the forecaster's own chance of this, stated with the estimate: 50%; the middle value is on the limit's open side.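

In this assay compound 4 gives only a limit (> 20000 nM). No new step can be read between compound 4 and compound 1, compound 2 or compound 3. Still open, as far as these compounds go, is where the true number of compound 4 lies, and whether pyridin-2-yl differs from the other groups on the triple-bonded carbon.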